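A few compounds are considered here, and "the series" means these few. Any claim that something is new, unique, unknown or untested is made for them only; others in the source may bear on it.

In an ADME assay on HEK-293T cells (Homo sapiens) for inhibition, read by MTT assay, with a stated time of 48 h (a higher number here means a weaker inhibitor, a lower number a stronger inhibitor), compound 1 `COc1cc(-c2nc3cc(/C=C4\SC(=O)N(Cc5ccccc5)C4=O)ccc3[nH]2)cc(OC)c1OC` gives 8210 nM, and compound 2 `COc1cc(-c2nc3cc(/C=C4\SC(=O)N(Cc5cccc(C)c5)C4=O)ccc3[nH]2)cc(OC)c1OC` gives 18900 nM, the higher of the two numbers. For the measured compounds named here, the one step measured so far, a 2.3-fold higher number from compound 1 to compound 2 (0.36 log units; beyond the scatter), came with a methyl in place of hydrogen on an aromatic carbon. Compound 3 `COc1cc(CN2C(=O)S/C(=C\c3ccc4[nH]c(-c5cc(OC)c(OC)c(OC)c5)nc4c3)C2=O)cc(OC)c1OC` carries a larger change: 3,4,5-trimethoxyphenyl in place of 3-methylphenyl on a saturated chain carbon bound to an amide-type nitrogen in a ring. Going by the values given here, no measured step tests this exchange directly, and the modest rise from compound 1 to compound 2 is the only guide. The step expected is a 1.2-fold higher number from compound 2 to compound 3 (0.07 log units; within the scatter), a small rise or none beyond the scatter. Compound 3 is therefore estimated at 22000 nM, with a range from 7000 nM to 70000 nM.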

Compound 3, half-maximal inhibitory concentration: 16600 nM
The estimate for compound 3 lay 1.3-fold (0.12 log units) above the measured number; the measured number falls inside the stated range.
By their numbers in this assay, from the lowest: compound 1; then compounds 3 and 2 (each within the scatter of the next).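

In this assay, this position accepts 3,4,5-trimethoxyphenyl in place of 3-methylphenyl with a 1.1-fold lower number from compound 2 to compound 3 (0.06 log units; within the scatter), so adding the methoxy groups and removing the methyl leaves the number within the scatter. Against the plain phenyl of compound 1, the same group gives a 2.0-fold higher number from compound 1 to compound 3 (0.31 log units; beyond the scatter), so both substituted rings shown read higher than the unsubstituted one. Nothing measured here explains these numbers. Still open, on these data alone, is how an amine or a carboxylic acid would read in place of these aromatic groups on the same carbon.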